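Pyridyl for Cyanofluorophenyl: Expected Microsomal Clearance

A few compounds are considered here, and "the series" means these few. Any claim that something is new, unique, unknown or untested is made for them only; others in the source may bear on it.

Compound 2 `CC(C)NC(=O)[C@H]1CC[C@@H](n2/c(=N/C(=O)c3ccc(C#N)c(F)c3)[nH]c3ccc(CN4CCC(C(C)(C)O)CC4)cc32)CC1` gives 29 mL.min-1.g-1 in an in vitro ADME assay on microsomes from liver (Rattus norvegicus) for metabolic stability (on this read-out lower numbers stand for slow clearance and higher numbers for fast clearance), standing at the top of the two numbers recorded, although compound 1 `CC(C)NC(=O)[C@H]1CC[C@@H](n2/c(=N/C(=O)c3ccc(F)c(F)c3)[nH]c3ccc(CN4CCC(C(C)(C)O)CC4)cc32)CC1` gives 19 mL.min-1.g-1 and the step of a 1.5-fold higher number from compound 1 to compound 2 (0.18 log units; within the scatter) stays within the scatter. Compound 3 `CC(C)NC(=O)[C@H]1CC[C@@H](n2/c(=N/C(=O)c3ccc(F)cc3)[nH]c3ccc(CN4CC(C(C)(C)O)C4)cc32)CC1` returns only a limit in this assay, < 14 mL.min-1.g-1, one of the values sitting at the limit of < 14 mL.min-1.g-1 in this assay, at which 1 of the 3 values shown sits. Compound 4 `CC(C)NC(=O)[C@H]1CC[C@@H](n2/c(=N/C(=O)c3cccnc3)[nH]c3ccc(CN4CCC(C(C)(C)O)CC4)cc32)CC1` differs from compound 2 by pyridin-3-yl in place of 4-cyano-3-fluorophenyl on a carbonyl carbon. Within the data shown here, the single measured step, cyano in place of fluoro, was small, and nothing measured tests pyridin-3-yl in place of 4-cyano-3-fluorophenyl, so no direction can be read from the data. Compound 4 is therefore expected to land near compound 2, with an estimated 25 mL.min-1.g-1 and a range from 12 mL.min-1.g-1 to 50 mL.min-1.g-1. The expected step of a 1.2-fold lower number from compound 2 to compound 4 (0.06 log units; within the scatter) would lie within the scatter.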

Compound 4, intrinsic clearance in microsomes: < 14 mL.min-1.g-1
Compound 4: a limit, no number (the forecaster's own chance of this, stated with the estimate: 20%); middle value at least 1.7-fold (0.25 log units) from the limit.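

Unlike the change from fluoro to cyano, pyridin-3-yl on this carbonyl carbon gives a step beyond the scatter in this assay, with an at least 2.0-fold lower number from compound 2 to compound 4 (0.31 log units; beyond the scatter). Measured against the 3,4-difluorophenyl group, the same ring shows less, with an at least 1.3-fold lower number from compound 1 to compound 4 (0.13 log units; that floor lies within the scatter), so only the comparison with 4-cyano-3-fluorophenyl separates clearly. The value of compound 4 is a limit, so neither step has an exact size: the limit of < 14 mL.min-1.g-1 in this assay, at which 2 of the 4 values shown sit.

As far as these compounds go, whether pyridin-2-yl, pyridin-4-yl or an unsubstituted phenyl on the same carbonyl carbon would also reach this limit remains open.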